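Ethylsulfonyl Extension on a Methoxy-Bearing Anilide

A few compounds are considered here, and "the series" means these few. Any claim that something is new, unique, unknown or untested is made for them only; others in the source may bear on it.

In an ADME assay on HEK293 cells (Homo sapiens) for cytotoxicity, read by MTT assay, with a stated time of 48 h (on this read-out higher numbers stand for weaker inhibition and lower numbers for stronger inhibition), compound 1 `Cc1cc(NC(=O)c2ccc(Cl)cc2)ccc1NS(C)(=O)=O` gives 50300 nM. Compound 2 `CCS(=O)(=O)Nc1ccc(NC(=O)c2ccc(Cl)cc2)cc1C` gives 125000 nM, so that a 2.5-fold higher number from compound 1 to compound 2 (0.40 log units; beyond the scatter). Compound 3 `COc1cc(NC(=O)c2ccc(Cl)cc2)ccc1NS(C)(=O)=O` reaches only the limit of the assay, > 250000 nM. Accordingly an at least 4.9-fold higher number from compound 1 to compound 3 (0.69 log units; beyond the scatter), and compound 3 is known only as sitting at the limit of > 250000 nM in this assay, at which 1 of the 3 values shown sits. Compound 4 `CCS(=O)(=O)Nc1ccc(NC(=O)c2ccc(Cl)cc2)cc1OC` differs from compound 3 by methyl in place of hydrogen on a saturated chain carbon bound to a sulfonyl sulfur. Among the compounds with values here, the one measured step of this kind, a 2.5-fold higher number from compound 1 to compound 2 (0.40 log units; beyond the scatter), was a modest weakening in this assay. A comparable weakening is therefore expected for compound 4, which would carry it further past the limit already reached by compound 3. Compound 4 is estimated at 500000 nM, between 200000 nM and 1500000 nM, an expected step that the limit leaves unreadable from compound 3 to compound 4.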

Compound 4, half-maximal inhibitory concentration: > 250000 nM
Compound 4: no number, only a limit (the forecaster's own chance of this, stated with the estimate: 85%); the middle value does not contradict the limit.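

With methoxy in place of methyl on an aromatic carbon, the ethylsulfonyl pair gives an at least 2.0-fold higher number from compound 2 to compound 4 (0.30 log units; that floor lies within the scatter) in this assay. The change has now been seen on two cores, but its size cannot be compared between them: the same change on two cores in this assay, an at least 4.9-fold higher number (0.69 log units; beyond the scatter) from compound 1 to compound 3 and an at least 2.0-fold higher number (0.30 log units; that floor lies within the scatter) from compound 2 to compound 4; the limit leaves it open whether they differ. Within the data shown here, no step that ends in two limits can be read, so the methyl in place of hydrogen cannot be sized on the methoxy core: the limit of > 250000 nM in this assay, at which 2 of the 4 values shown sit. As far as these compounds go, what remains open is how far compound 3 and compound 4 actually differ, and whether a longer chain on the sulfonyl sulfur, or an amine in place of the methoxy, would give a readable number.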